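Working notes on a four-compound cytotoxicity series

This account rests on a few compounds, and the source may have more. Where it says the series, first, only, none or still open, it means among the compounds named here.

Compound 1 `Cc1nnc(SCC(=O)c2ccc(Cl)cc2)n1N1C(=O)c2ccccc2C1=O` serves as the reference point. In a functional assay on HepG2 cells (Homo sapiens) for cytotoxicity, read by MTT assay, with a stated time of 48 h (a higher number here means a weaker inhibitor, a lower number a stronger inhibitor), compound 1 gives only a limit, > 200000 nM. Compound 2 `Cc1ccc(C(=O)CSc2nnc(C)n2N2C(=O)c3ccccc3C2=O)cc1` differs from it by methyl in place of chloro on an aromatic carbon. In this assay compound 2 likewise gives only a limit, > 200000 nM. Compound 3 `CCc1nnc(SCC(=O)c2ccc(Cl)cc2)n1N1C(=O)c2ccccc2C1=O` differs from compound 1 in the core by methyl in place of hydrogen on a saturated chain carbon bound to an aromatic carbon. In this assay compound 3 again gives only a limit, > 200000 nM. Both a step that the two limits leave unreadable from compound 1 to compound 2 and a step that the two limits leave unreadable from compound 1 to compound 3 therefore cannot be sized from these values. Compound 4 `CCc1nnc(SCC(=O)c2ccc(C)cc2)n1N1C(=O)c2ccccc2C1=O` is not yet measured; it differs from compound 3 by methyl in place of chloro on an aromatic carbon, the same change as from compound 1 to compound 2, at the same place. Given (the limit of > 200000 nM in this assay, at which 3 of the 3 values shown sit), compound 4 is expected to sit at the limit as well, with an estimated step that the limit leaves unreadable from compound 3 to compound 4 beside the earlier one. Compound 4 is estimated at 300000 nM in this assay.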

Compound 4, half-maximal inhibitory concentration: > 200000 nM
Compound 4 was reported as a limit; the forecaster's own chance of this, stated with the estimate: 85%; the middle value does not contradict the limit.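

In this assay compound 4 gives the limit > 200000 nM and its steps from compound 3 and compound 2 cannot be read: the limit of > 200000 nM in this assay, at which 4 of the 4 values shown sit.

In this assay the compounds shown leave open which change, if any, would give a readable value rather than a limit.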